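Para-methoxy on the phenyl ring of a chlorinated tetrahydropyran

This account rests on a few compounds, and the source may have more. Where it says the series, first, only, none or still open, it means among the compounds named here.

Measured compounds:
Compound 1, `CC(C)C[C@H]1C[C@@H](Cl)C[C@@H](C2CCCCC2)O1`: 63000 nM
Compound 2, `CC(C)C[C@H]1C[C@@H](Cl)C[C@@H](c2ccccc2)O1`: 88000 nM

Two compounds from this series share a core that carries an isobutyl chain and a chlorine on a saturated six-membered oxygen ring, and differ only in the group at the remaining position. In a functional assay on WiDr cells (Homo sapiens) for antiproliferative activity (a higher number here means a weaker inhibitor of growth, a lower number a stronger inhibitor of growth), compound 1, which carries a cyclohexyl group there, gives 63000 nM. In this assay compound 2, with a phenyl ring instead, gives 88000 nM. The two numbers lie within the usual scatter of each other, so neither compound can be said to inhibit growth more strongly than the other; both are weak inhibitors.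

Compound 3, `COc1ccc([C@@H]2C[C@H](Cl)C[C@H](CC(C)C)O2)cc1`, is not yet measured. It differs from compound 2 by methoxy in place of hydrogen on an aromatic carbon. Going by the values given here, no pair of measured compounds shows the effect of such a change, so there is no measured step to lean on. The step from compound 2 to compound 3 in this assay is expected to be small, most likely not beyond the scatter, with a slight lean toward stronger inhibition, which is what a 1.5-fold lower number from compound 2 to compound 3 (0.17 log units; within the scatter) expresses. Compound 3 is therefore estimated at 60000 nM, with a range from 20000 nM to 180000 nM.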

Compound 3, concentration for total growth inhibition: 73000 nM
Compound 3: middle estimate off by 1.2-fold (0.09 log units), on the low side; measured number inside the range.
By their numbers in this assay, from the lowest: compounds 1, 3 and 2 (each within the scatter of the next).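

Putting methoxy in place of hydrogen on an aromatic carbon, para to a large group, gives a 1.2-fold lower number from compound 2 to compound 3 (0.08 log units; within the scatter) in this assay. Going by these compounds alone, this is the first measured example of this change, and it shows that this position accepts methoxy with no readable effect on growth inhibition: compound 3 cannot be told apart from compound 2 and, like the earlier compounds, remains a weak inhibitor. No other measurement bears on this result, so the data offer no explanation of it.

From the compounds shown here alone, whether an amine or a carboxylic acid in the same place would move the number beyond the scatter remains open, as does whether methoxy would behave the same way on another carbon of the aromatic ring. The compounds shown also keep the chlorine and the isobutyl chain unchanged, so the effect of a hydroxyl group in place of that chlorine, or of a longer chain in place of the isobutyl chain, on the result in this assay is unknown.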